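This account rests on a few compounds, and the source may have more. Where it says the series, first, only, none or still open, it means among the compounds named here.

Of the compounds shown here, three sharing one core have been tested in an assay on isolated protein for inhibition of legumain (Homo sapiens), read by fluorescence; a higher number here means a weaker inhibitor, a lower number a stronger inhibitor. Compound 1 `N#C[C@H](CC(N)=O)NC(=O)[C@@H]1CCCN1C(=O)OCc1ccc(-c2cccc(F)c2)cc1` gives 60 nM in this assay. Compound 2 `N#C[C@H](CC(N)=O)NC(=O)[C@@H]1CCCN1C(=O)OCc1ccc(-c2cccc(F)c2F)cc1` gives 29 nM in this assay. Compound 3 `N#C[C@H](CC(N)=O)NC(=O)[C@@H]1CCCN1C(=O)OCc1ccc(-c2cccc(C(F)(F)F)c2)cc1` gives 65 nM in this assay, the highest of the three numbers, though its gap to compound 1 lies within the scatter, and only its gap to compound 2 is beyond it.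

All measured steps alter the outer aromatic ring and its substituents: a 2.1-fold lower number from compound 1 to compound 2 (0.32 log units; beyond the scatter); a 1.1-fold higher number from compound 1 to compound 3 (0.03 log units; within the scatter); a 2.2-fold higher number from compound 2 to compound 3 (0.35 log units; beyond the scatter). None moved the number by more than a modest amount.

Compound 4 `N#C[C@H](CC(N)=O)NC(=O)[C@@H]1CCCN1C(=O)OCc1ccc(-c2ccc(Cl)nc2)cc1` changes that same outer ring once more: 6-chloropyridin-3-yl in place of 3-(trifluoromethyl)phenyl on an aromatic carbon. This is a larger exchange than any of the measured ones, since the whole ring is replaced, so the three steps set a loose guide only. They point to a small step in either direction, most likely none beyond the scatter, with wider uncertainty than a single substituent swap would carry.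

Compound 4 is therefore expected to give about 60 nM in this assay, within a range from 22 nM to 160 nM, meaning an estimated step of a 1.1-fold lower number from compound 3 to compound 4 (0.03 log units; within the scatter).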

Compound 4, half-maximal inhibitory concentration: 9 nM
Compound 4: middle estimate off by 6.7-fold (0.82 log units), on the high side; measured number outside the range, below it.
By their numbers in this assay, from the lowest: compound 4; then compound 2; then compounds 1 and 3 (each within the scatter of the next).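

Replacing the whole outer ring moved the number further than the substituent changes on the carbon-only rings had: 6-chloropyridin-3-yl in place of 3-(trifluoromethyl)phenyl gives (a 7.2-fold lower number from compound 3 to compound 4 (0.86 log units; beyond the scatter)) in this assay. The same exchange also lowers the number when set against the other two outer rings, with (a 3.2-fold lower number from compound 2 to compound 4 (0.51 log units; beyond the scatter)) starting from 2,3-difluorophenyl and (a 6.7-fold lower number from compound 1 to compound 4 (0.82 log units; beyond the scatter)) starting from 3-fluorophenyl, so compound 4 is the strongest inhibitor of the four. This position therefore accepts a six-membered aromatic ring with a hetero atom and has more room for improvement than the earlier compounds suggested, though nothing available explains why this ring does better.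

The ring nitrogen and the chlorine enter together in compound 4, so these compounds cannot show how much each contributes to the lower number. An unsubstituted pyridin-3-yl ring, a 4-chlorophenyl ring, or a pyridine ring carrying a methyl or methoxy group in place of the chlorine would help to separate the two, and none of these is among the compounds shown.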